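This account rests on a few compounds, and the source may have more. Where it says the series, first, only, none or still open, it means among the compounds named here.

Compound 1 `COc1ccc(S(=O)(=O)c2cnc3cc(F)ccc3c2-c2ccc(Cl)cc2)cc1`: 1.28 mL/min
Compound 2 `COc1ccc(S(=O)(=O)c2cnc3cc(F)ccc3c2-c2cccc(F)c2)cc1Cl`: 2.08 mL/min
Compound 3 `COc1ccc(S(=O)(=O)c2cnc3cc(F)ccc3c2-c2cccc(F)c2)cc1`: 2.94 mL/min

In an ADME assay on microsomes from liver (Homo sapiens) for metabolic stability, tested at 2.5 uM (on this read-out higher numbers stand for fast clearance and lower numbers for slow clearance), compound 3 lies beyond the scatter above compound 1 a 2.3-fold higher number from compound 1 to compound 3 (0.36 log units; beyond the scatter), whereas compound 2 sits within the scatter of it a 1.4-fold higher number from compound 2 to compound 3 (0.15 log units; within the scatter). Compound 4 `N#Cc1cccc(S(=O)(=O)c2cnc3cc(F)ccc3c2-c2cccc(F)c2)c1` is not yet measured; it differs from compound 3 by 3-cyanophenyl in place of 4-methoxyphenyl on a sulfonyl sulfur. For the measured compounds named here, only the step between compound 2 and compound 3 touches the ring on the sulfonyl sulfur, and that step stayed within the scatter; the other step concerns the other aryl ring. Going by the values given here, no measured step swaps the whole ring on the sulfonyl sulfur. Compound 4 is therefore expected to stay near compound 3, with a step of a 1.2-fold lower number from compound 3 to compound 4 (0.07 log units; within the scatter) that is not expected to clear the scatter. The estimate for compound 4 is 2.5 mL/min, between 1.1 mL/min and 5.5 mL/min.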

Compound 4, intrinsic clearance in a liver preparation (reported as CLH), per the amount of preparation that the assay uses: 0.78 mL/min
Compound 4: the middle estimate sits 3.2-fold (0.51 log units) above what was measured; measured number below the stated range.
By their numbers in this assay, from the lowest: compounds 4, 1, 2 and 3 (each within the scatter of the next, the first and the last beyond it).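

In this assay, the ring on the sulfonyl sulfur proved able to move the number beyond the scatter, which the loss of chloro from that ring had not done: 3-cyanophenyl in place of 4-methoxyphenyl gives (a 3.8-fold lower number from compound 3 to compound 4 (0.58 log units; beyond the scatter)), and 3-cyanophenyl in place of 3-chloro-4-methoxyphenyl gives (a 2.7-fold lower number from compound 2 to compound 4 (0.43 log units; beyond the scatter)). No measurement at hand accounts for this change. The compounds shown leave open whether the nitrile or the loss of the methoxy group carries the step, since the two come together here. They also leave open how an aryl ring bearing an amine or a carboxylic acid would behave on the sulfonyl sulfur.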